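This account rests on a few compounds, and the source may have more. Where it says the series, first, only, none or still open, it means among the compounds named here.

Series notes. Compound 1 `ClCc1ccc(Cn2cnc3c(Cl)ncnc32)cc1` and compound 3 `ClCc1ccc(Cn2cnc3c(Cl)nc(Cl)nc32)cc1` share one core; compound 2 `ClCc1cccc(Cn2cnc3ncnc(Cl)c32)c1` has the same atoms joined differently, and the difference between the two cores is not broken down here. Compound 4 `ClCc1cccc(Cn2cnc3nc(Cl)nc(Cl)c32)c1` is not yet measured. In a functional assay on UACC-62 cells (Homo sapiens) for cytotoxicity, read by sulforhodamine B assay, with a stated time of 48 h (on this read-out higher numbers stand for lower toxicity in this test and lower numbers for higher toxicity in this test), compound 1 gives 9450 nM and compound 3 gives 9330 nM. The change from compound 1 to compound 3 is chloro in place of hydrogen on an aromatic carbon, and the step it made is a 1.0-fold lower number from compound 1 to compound 3 (0.01 log units; within the scatter). In this assay compound 2 gives 38900 nM, the highest number of the three measured, and its gap to compound 1 and to compound 3 lies beyond the usual scatter, so compound 2 reads as the least toxic of the three. Compound 4 carries the same change from compound 2: chloro in place of hydrogen on an aromatic carbon. The two place descriptions agree word for word, so this is the same change, occurring twice among the compounds shown. Among the compounds with values here, its one measured instance left the number essentially unchanged, so from compound 2 to compound 4 a step of a 1.1-fold lower number from compound 2 to compound 4 (0.02 log units; within the scatter) is expected, resting on a 1.0-fold lower number from compound 1 to compound 3 (0.01 log units; within the scatter). Compound 4 is accordingly estimated at 37000 nM in this assay, with an expected range from 15000 nM to 90000 nM.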

Compound 4, concentration lethal to 50% of the cells: 4670 nM
Estimate against measurement, compound 4: 7.9-fold (0.90 log units) above; the whole stated range lies above it.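

In this assay, chloro in place of hydrogen on an aromatic carbon, placed between two ring nitrogen atoms, gives an 8.3-fold lower number from compound 2 to compound 4 (0.92 log units; beyond the scatter), so this change moves the number on the core of compound 2 but not on the core of compound 1: the same change on two cores in this assay, a 1.0-fold lower number (0.01 log units; within the scatter) from compound 1 to compound 3 and an 8.3-fold lower number (0.92 log units; beyond the scatter) from compound 2 to compound 4, 8.2-fold (0.92 log units) apart, beyond the scatter of two such steps

The size of this step therefore does not carry from one core to the other in this series, and a step read on one core gives no safe estimate for the other. Within the data shown here, with a single pair on each core, this shows only that the two steps differ; it neither explains the difference nor sets a rule for any further compound.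

The compounds shown leave open whether an amine or a methoxy group at that ring carbon would also give steps that differ on the two cores. They also leave open whether the two cores would still differ with a hydroxymethyl group in place of the chloromethyl group on the benzene ring.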